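This account rests on a few compounds, and the source may have more. Where it says the series, first, only, none or still open, it means among the compounds named here.

Three compounds share one core and differ only in the group on an aromatic nitrogen. Compound 1 `Cn1c(=O)c2c(nnn2C2CCCC2)n(C)c1=O` gives 11000 nM in an assay on cell membranes from brain for displacement of a labelled ligand from adenosine receptor A1 (Bos taurus); a lower number here means a stronger inhibitor, a higher number a weaker inhibitor. Compound 2 `Cn1c(=O)c2nn(C3CCCCC3)nc2n(C)c1=O` gives 36000 nM in this assay. Compound 3 `Cn1c(=O)c2c(nnn2C2CCCCC2)n(C)c1=O` gives 23000 nM in this assay. Among these three numbers compound 3 stands second highest; its number and that of compound 2 lie within the scatter of each other, while the only measured step, a 2.1-fold higher number from compound 1 to compound 3 (0.32 log units; beyond the scatter), sets compound 3 apart from compound 1.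

Compound 4 `Cn1c(=O)c2c(nnn2C2CCCCC2O)n(C)c1=O` has not yet been measured in this assay. It differs from compound 3 by hydroxy in place of hydrogen on a saturated ring carbon. Within the data shown here, no measured step covers a change of this kind: the single step in hand, a 2.1-fold higher number from compound 1 to compound 3 (0.32 log units; beyond the scatter), concerns the size of the saturated ring and not a group placed on it, so it offers neither a direction nor a size for compound 4. With nothing else to lean on, compound 4 is expected to come out close to the number of compound 3. The expected step is no change at the digits printed from compound 3 to compound 4 (within the scatter), within the scatter. The value of compound 4 in this assay is therefore estimated at 23000 nM, with a range from 7000 nM to 75000 nM to reflect the absence of any guiding step.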

Compound 4, inhibition constant: 114000 nM
The estimate for compound 4 lay 5.0-fold (0.70 log units) below the measured number, outside the stated range (above it).
By their numbers in this assay, from the lowest: compound 1; then compounds 3 and 2 (each within the scatter of the next); then compound 4.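

In this assay, hydroxy in place of hydrogen on a saturated ring carbon gives a 5.0-fold higher number from compound 3 to compound 4 (0.70 log units; beyond the scatter), so this carbon of the six-membered ring, next to the ring atom that bears a large group, is sensitive to substitution, and this change moves the number towards weaker inhibition. Among these compounds, the only earlier step, a 2.1-fold higher number from compound 1 to compound 3 (0.32 log units; beyond the scatter), concerned the size of the saturated ring; the new step shows that placing a single group on that ring moves the number further in the same direction. Nothing at hand explains this weakening.

A single group at a single ring carbon leaves open whether the shift belongs to hydroxy itself or would follow any group placed there, and methyl, methoxy, fluorine or an amine at this carbon would be needed to tell these readings apart. Also open, from the compounds shown here alone, is whether hydroxy on the cyclopentyl ring of compound 1 would give a step of similar direction and size.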